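From benzyloxy to pyridin-4-yl: estimating the change

A few compounds are considered here, and "the series" means these few. Any claim that something is new, unique, unknown or untested is made for them only; others in the source may bear on it.

Measured in an ADME assay on microsomes (Mus musculus) for metabolic stability; a higher number here means faster removal of the compound, a lower number slower removal:
- compound 1 `CNC(=O)[C@@H]1CCCN1S(=O)(=O)c1ccc(Cl)c(COc2cccc3c(-c4cncn4C)cc(C)nc23)c1Cl`: 117 mL/min/kg
- compound 2 `CNC(=O)[C@@H]1CCCN1S(=O)(=O)c1ccc(Cl)c(COc2cccc3c(OCc4ccccc4)cc(C)nc23)c1Cl`: 1820 mL/min/kg

Compound 2 has the higher of these two numbers, so it is the faster-removed of the pair. Compound 3 `CNC(=O)[C@@H]1CCCN1S(=O)(=O)c1ccc(Cl)c(COc2cccc3c(-c4ccncc4)cc(C)nc23)c1Cl` keeps the shared core and changes one group: pyridin-4-yl in place of benzyloxy on an aromatic carbon. The swap puts pyridin-4-yl in place of benzyloxy on an aromatic carbon, opposite the ring nitrogen. Within the data shown here, one measured step bears on it: a 16-fold higher number from compound 1 to compound 2 (1.19 log units; beyond the scatter), a large change beyond the scatter, with benzyloxy in place of 1-methyl-1H-imidazol-5-yl. From the compounds shown here alone, compound 3 also lacks benzyloxy, so a large fall in this assay is expected, though pyridin-4-yl itself is untested and a single step is thin evidence. The expected change is a 9.1-fold lower number from compound 2 to compound 3 (0.96 log units; beyond the scatter). For compound 3 the estimated value is 200 mL/min/kg, with an expected range of 70 mL/min/kg to 600 mL/min/kg.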

Compound 3, clearance: 550 mL/min/kg
For compound 3 the middle estimate is 2.8-fold (0.44 log units) below the measured one; low and high end bracket the measured number.
By their numbers in this assay, from the lowest: compound 1; then compound 3; then compound 2.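

Measured in this assay the swap to pyridin-4-yl opposite the ring nitrogen gives a 3.3-fold lower number from compound 2 to compound 3 (0.52 log units; beyond the scatter) and this shows that a number well below that of compound 2 can be reached with a six-membered aromatic ring at this position. Removing benzyloxy is not the whole story, though, since the group that replaces it also matters. Exchanging one aromatic ring for another at the same carbon gives a 4.7-fold higher number from compound 1 to compound 3 (0.67 log units; beyond the scatter) and so pyridin-4-yl and 1-methyl-1H-imidazol-5-yl are not interchangeable here, with compound 1 remaining the lowest of the three.

Nothing available here explains why these groups differ. From the compounds shown here alone, what also stays open is how this position would respond to an amine, a carboxylic acid or a longer carbon chain in place of these rings.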